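The compounds below may be only part of what the source reports. "The series", "measured", "known", "first", "only" and "open" are said of these compounds alone.

Of the compounds shown here, two have so far been read in a functional assay on L5178Y cells (Mus musculus) for inhibition, read by MTT assay, with a stated time of 72 h; a higher number here means a weaker inhibitor, a lower number a stronger inhibitor. Compound 1 `C[Se]C(=O)c1cccc(C(=O)[Se]C)c1` gives > 100000 nM, which is a limit and not a number. Among the measured compounds shown here, compound 2 `COC(=O)C[Se]C(=O)c1ccc(Cl)cc1` gives 87800 nM, the only actual number so far. Compound 3 `CC(=O)C[Se]C(=O)c1ccc(Cl)cc1` carries methyl in place of methoxy on a carbonyl carbon, reading as methoxycarbonyl to acetyl (methyl in place of methoxy on a carbonyl carbon). No measured step sizes this change, so the expectation is loosely held. With compound 2 at 87800 nM, a move toward stronger inhibition is expected, and the estimated 4.4-fold lower number from compound 2 to compound 3 (0.64 log units; beyond the scatter) lies beyond the scatter. The estimated value for compound 3 is 20000 nM, with an expected range of 3000 nM to 90000 nM.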

Compound 3, half-maximal inhibitory concentration: 1030 nM
Compound 3: the middle estimate sits 19-fold (1.29 log units) above what was measured; measured number below the stated range.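

In this assay, among the compounds shown here, replacing methoxy with methyl on a carbonyl carbon gives an 85-fold lower number from compound 2 to compound 3 (1.93 log units; beyond the scatter) and supplies the first readable step. The change from (methoxycarbonyl)methyl to 2-oxopropyl, with the rest of the structure shared, is therefore enough to move inhibition far beyond the scatter. One value in the series remains a limit and not a number: the limit of > 100000 nM in this assay, at which 1 of the 3 values shown sits.

A single pair cannot show whether this large step is specific to acetyl. Longer-chain ketones, an amide or a carboxylic acid at this carbonyl carbon remain open.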